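The compounds below may be only part of what the source reports. "The series", "measured", "known", "first", "only" and "open" are said of these compounds alone.

Measured in a functional assay on ZR-75-1 cells (Homo sapiens) for inhibition, read by sulforhodamine B assay; a lower number here means a stronger inhibitor of growth, a higher number a weaker inhibitor of growth:

- compound 1 `FC(F)(F)Oc1ccc(-c2ccc(-c3ccc(-c4nc5ccccc5[nH]4)cc3)cc2)cc1`: 100000 nM
- compound 2 `Oc1ccc(-c2ccc(-c3ccc(-c4nc5ccccc5[nH]4)cc3)cc2)cc1`: 100000 nM
- compound 3 `COc1ccc(-c2ccc(-c3ccc(-c4nc5ccccc5[nH]4)cc3)cc2)cc1`: 35100 nM

Compound 3 has the lowest number of the three, which makes it the strongest growth inhibitor so far, though only by modest margins: a 2.8-fold lower number from compound 1 to compound 3 (0.45 log units; beyond the scatter) and a 2.8-fold lower number from compound 2 to compound 3 (0.45 log units; beyond the scatter).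

Compound 4 `COc1ccc(-c2ccc(-c3ccc(-c4nc5c(O)cccc5[nH]4)cc3)cc2)cc1` has hydroxy in place of hydrogen on an aromatic carbon, which turns 1H-benzimidazol-2-yl into 4-hydroxy-1H-benzimidazol-2-yl: hydroxy in place of hydrogen on an aromatic carbon.

Among the measured compounds shown here, no measured step touches this part of the molecule. The nearest guides are the two steps above and no change at the digits printed from compound 1 to compound 2 (within the scatter), all of which change a group on an oxygen on an aromatic ring elsewhere in the structure. They show that single small changes in this series have so far moved this assay only modestly or not beyond the scatter, but they give no firm direction for the new hydroxy. The expected result is therefore a 1.2-fold lower number from compound 3 to compound 4 (0.07 log units; within the scatter), with real uncertainty on both sides. For compound 4 the estimated value is 30000 nM, with an expected range from 5000 nM to 100000 nM.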

Compound 4, concentration for 50% growth inhibition: 8200 nM
Compound 4: middle estimate off by 3.7-fold (0.56 log units), on the high side, and the stated range covers the measured number.
By their numbers in this assay, from the lowest: compound 4; then compound 3; then compounds 1 and 2 (each within the scatter of the next).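

In this assay, hydroxy in place of hydrogen, which turns 1H-benzimidazol-2-yl into 4-hydroxy-1H-benzimidazol-2-yl, gives a 4.3-fold lower number from compound 3 to compound 4 (0.63 log units; beyond the scatter) and leaves compound 4 with the lowest number of the four. Among the compounds shown here, the earlier steps changed only the group on an oxygen on an aromatic ring, so this is the first sign that the fused part of the molecule can also shift growth inhibition beyond the scatter, though the step is still modest. Nothing measured here gives a reason for this shift.

The compounds shown leave open whether another group at this place, such as methoxy, an amine or fluorine, would give a lower or a higher number than hydroxy. They also leave open whether the new hydroxy would lower the number to the same extent in compound 1 or compound 2.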